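Amide for Acid in Agonists of a Fatty Acid Receptor

The compounds below may be only part of what the source reports. "The series", "measured", "known", "first", "only" and "open" are said of these compounds alone.

Compound 1 `CC(CC(=O)O)c1ccc(NCc2cccc(Oc3ccccc3)c2)cc1` and compound 2 `Cc1nc(-c2ccc(C(F)(F)F)cc2)sc1CNc1ccc(C(C)CC(=O)O)cc1` share a common amine-linked propanoic acid motif but differ elsewhere; how the two cores differ is not broken down here. In a functional assay on CHO cells for agonist activity at Free fatty acid receptor 1 (Homo sapiens), read by a luciferase reporter (a lower number here means a smaller maximal response, a higher number a larger maximal response), compound 1 gives 83%, while compound 2 gives 109%, the highest of the three measured values. Compound 3 `NC(=O)CCc1ccc(NCc2cccc(Oc3ccccc3)c2)cc1` carries the change (2-carbamoylethyl in place of 1-(carboxymethyl)ethyl on an aromatic carbon), and in this assay compound 3 gives 68%, a step of a number 15 percentage points lower from compound 1 to compound 3 (beyond the scatter). Compound 4 `Cc1nc(-c2ccc(C(F)(F)F)cc2)sc1CNc1ccc(CCC(N)=O)cc1` carries the same kind of change on the core of compound 2, (2-carbamoylethyl in place of 1-(carboxymethyl)ethyl on an aromatic carbon). A step of a number 17 percentage points lower from compound 2 to compound 4 (beyond the scatter) is expected in this assay, resting on the modest loss seen in a number 15 percentage points lower from compound 1 to compound 3 (beyond the scatter). Compound 4 is therefore estimated at 92%, between 76% and 106%.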

Compound 4, largest response reached (reported as percent of maximum), in percent of the reference or control that the assay uses: 88%
Beside the measured number, compound 4's estimate is 4 percentage points above it, and the stated range covers the measured number.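

In this assay the change again lowers the maximal response, with a number 21 percentage points lower from compound 2 to compound 4 (beyond the scatter). Set beside the earlier step, the change carries over from one core to the other with no difference in size beyond the scatter: the same change on two cores in this assay, a number 15 percentage points lower (beyond the scatter) from compound 1 to compound 3 and a number 21 percentage points lower (beyond the scatter) from compound 2 to compound 4, 6 percentage points apart, within the scatter of two such steps. This agreement rests on two cores only; it does not show that the step would hold on a third core, or which part of the exchanged group accounts for it.

The compounds shown leave open how a 2-carboxyethyl group, a carboxylic acid on an unbranched chain, would compare, which would separate the end group from the branch. From the compounds shown here alone, an amine or a longer chain at the same place also remains open.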